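Fluoro for Methyl on a Shared Core: Expected Cytotoxicity

The source may hold more compounds than are shown below. What is called first, only, known or untested is meant among the compounds shown, and "the series" means these compounds.

Measured compounds:
compound 1, `O=C1CSC(c2cccc(O)c2)N1CCN1CCCCC1`: 100%
compound 2, `Cc1ccc(C2SCC(=O)N2CCN2CCCCC2)cc1`: 100%

In an ADME assay on Vero cells (Chlorocebus sabaeus) for cytotoxicity, read by neutral red uptake, tested at 25 ug/mL (a higher number here means a weaker effect of the compound at the concentration tested, a lower number a stronger effect), compound 1 gives 100%. In this assay compound 2 gives 100%. Among the compounds with values here, the only measured step, no change at the digits printed from compound 1 to compound 2 (within the scatter), placed 4-methylphenyl in place of 3-hydroxyphenyl on a saturated ring carbon and stayed within the scatter, so compound 2 stands level with compound 1 on these numbers. Compound 3, `O=C1CSC(c2ccc(F)cc2)N1CCN1CCCCC1`, differs from compound 2 by fluoro in place of methyl on an aromatic carbon. Within the data shown here, the single known step bears on this change only loosely, as it altered the group on the saturated ring carbon rather than a substituent on the aromatic ring, but it was flat, and the two values give no sign that the read-out responds to such changes. Compound 3 is therefore expected to show no step beyond the scatter in this assay, that is no change at the digits printed from compound 2 to compound 3 (within the scatter). The estimate for compound 3 is 100%, with a range from 85% to 100%.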

Compound 3, a percentage reported as activity, at one concentration (the size of the read-out at that concentration, not a potency): 100%
For compound 3 middle estimate and measured number coincide at the digits printed; measured number inside the range.
By their numbers in this assay, from the lowest: compounds 1, 2 and 3 (each within the scatter of the next).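

A change on the aromatic carbon itself now has a reading: in this assay, fluoro in place of methyl, para to a large group, gave no change at the digits printed from compound 2 to compound 3 (within the scatter) on the shared core, whereas the earlier step had exchanged the whole group on the saturated ring carbon. A second exchange of that kind, 4-fluorophenyl in place of 3-hydroxyphenyl, gave no change at the digits printed from compound 1 to compound 3 (within the scatter) and so matched the earlier flat step, with none of the three compounds going against this. Nothing available explains why the read-out stays level across these groups.

Going by these compounds, it remains open whether a carboxylic acid, an amine or a trifluoromethyl group on the same aromatic carbon would move the read-out in this assay at all. With all three compounds level at a single concentration, these values also cannot rank them.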